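The source may hold more compounds than are shown below. What is called first, only, known or untested is meant among the compounds shown, and "the series" means these compounds.

Among the measured compounds shown here, in a functional assay on HT-29 cells (Homo sapiens) for cytotoxicity, read by sulforhodamine B assay (on this read-out higher numbers stand for weaker inhibition of growth and lower numbers for stronger inhibition of growth), compound 1 (`CC1=CC[C@@H]([C@@](C)(O)CCCC(C)(C)NC=S)CC1`) gives 11400 nM and compound 2 (`CC1=CC[C@@H]([C@@](C)(O)CCCC(C)(C)NC(=S)N/N=C\c2ccc(O)cc2)CC1`) gives 8150 nM, while compound 3 (`CC1=CC[C@@H]([C@@](C)(O)CCCC(C)(C)NC(=S)N/N=C\c2ccccc2[N+](=O)[O-])CC1`) gives 6940 nM on the numbers so far. These three values lie within the usual scatter of one another, so compound 3 cannot be separated from either of the other two. Compound 4 (`CC1=CC[C@@H]([C@@](C)(O)CCCC(C)(C)NC(=S)N/N=C\c2ccc(Cl)cc2)CC1`) carries 4-chlorophenyl in place of 2-nitrophenyl on a carbon with a double bond to nitrogen and is otherwise the same as compound 3. For the measured compounds named here, only one measured step bears on that place, namely a 1.2-fold lower number from compound 2 to compound 3 (0.07 log units; within the scatter) on exchanging 4-hydroxyphenyl for 2-nitrophenyl. Going by the values given here, that exchange stayed within the scatter, so the one available precedent shows little response to the group carried there. Among the compounds with values here, it is thin evidence, as no compound with a chlorine on this ring has yet been measured. No change beyond the scatter is therefore expected, in either direction, and the expected step is a 1.0-fold higher number from compound 3 to compound 4 (0.00 log units; within the scatter) on this estimate. In this assay compound 4 is estimated at 7000 nM (expected range 3500 nM to 14000 nM).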

Compound 4, concentration for 50% growth inhibition: 7350 nM
The estimate for compound 4 lay 1.1-fold (0.02 log units) below the measured number; low and high end bracket the measured number.
By their numbers in this assay, from the lowest: compounds 3, 4, 2 and 1 (each within the scatter of the next).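

In this assay the group on a carbon with a double bond to nitrogen has now been exchanged a second time, and 4-chlorophenyl in place of 2-nitrophenyl gives a 1.1-fold higher number from compound 3 to compound 4 (0.02 log units; within the scatter) while chloro in place of hydroxy on an aromatic carbon gives a 1.1-fold lower number from compound 2 to compound 4 (0.04 log units; within the scatter) in the same series. Where the earlier compounds offered a single exchange at this place, 4-hydroxyphenyl, 2-nitrophenyl and 4-chlorophenyl now form a set of three that this read-out cannot separate. Among the compounds shown here, the second step also adds something of a different kind, since it changes only one substituent on the ring rather than the whole aryl group, and that smaller change stays within the scatter as well.

As far as these compounds go, all three groups at this place are substituted phenyl rings, so it remains open whether a pyridine ring, or a phenyl ring carrying an amine or a carboxylic acid, would move the number beyond the scatter. From the compounds shown here alone, it also remains open whether a carbonyl in place of the thiocarbonyl of the shared core would leave the growth inhibition unchanged, and no measurement at hand offers a reason for the flat response at this place.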